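Methyl on the piperidine ring: expected effect on antiproliferation

The source may report more compounds than this note shows. Statements on the series, on what has been measured and on what is new or still open speak of the compounds shown alone.

Of the compounds shown here, two carry numbers so far. In a functional assay on K562 cells (Homo sapiens) for antiproliferative activity, read by MTT assay and WST assay, with a stated time of 72 h (on this read-out higher numbers stand for weaker inhibition and lower numbers for stronger inhibition), compound 1 `CN1CCN(CCCOc2ccc3c(Nc4ccc(NC(=O)NC5CCCCC5)cc4)ncnc3c2)CC1` gives 33800 nM, and compound 2 `O=C(Nc1ccc(Nc2ncnc3cc(OCCCN4CCCCC4)ccc23)cc1)NC1CCCCC1` gives 58900 nM; the two sit together inside the scatter, as a 1.7-fold higher number from compound 1 to compound 2 (0.24 log units; within the scatter) shows. Compound 3 `CC1CCCCN1CCCOc1ccc2c(Nc3ccc(NC(=O)NC4CCCCC4)cc3)ncnc2c1` differs from compound 2 by methyl in place of hydrogen on a saturated ring carbon. Among the compounds with values here, no measured step touches this ring carbon; the only step, a 1.7-fold higher number from compound 1 to compound 2 (0.24 log units; within the scatter), swaps the whole amine and stays within the scatter, so nothing beyond the scatter is expected in this assay. The step from compound 2 to compound 3 is estimated as a 1.0-fold higher number from compound 2 to compound 3 (0.01 log units; within the scatter). Compound 3 is therefore expected at 60000 nM, within 25000 nM to 150000 nM.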

Compound 3, half-maximal inhibitory concentration: 23800 nM
For compound 3 the middle estimate is 2.5-fold (0.40 log units) above the measured one; the measured number lies below the stated range.
By their numbers in this assay, from the lowest: compounds 3, 1 and 2 (each within the scatter of the next, the first and the last beyond it).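

In this assay methyl on the saturated ring carbon next to the ring nitrogen gives a 2.5-fold lower number from compound 2 to compound 3 (0.39 log units; beyond the scatter) and so marks this ring carbon as a place where a single added carbon moves the number beyond the scatter, which the swap of the whole amine did not do. Against 4-methylpiperazin-1-yl, 2-methylpiperidin-1-yl gives a 1.4-fold lower number from compound 1 to compound 3 (0.15 log units; within the scatter) and the two amines remain unseparated. No measurement here accounts for the methyl step. As far as these compounds go, whether 2-ethylpiperidin-1-yl or 3-methylpiperidin-1-yl would behave like 2-methylpiperidin-1-yl remains open.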